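The source may report more compounds than this note shows. Statements on the series, on what has been measured and on what is new or still open speak of the compounds shown alone.

Compound 3 `COc1ccc(C(O)c2c(C)oc3c([C@H]4CCN(C)C[C@H]4O)c(O)cc(O)c3c2=O)cc1Br` stands highest of the three measured compounds in a functional assay on MCF7 cells (Homo sapiens) for inhibition, read by MTT assay, with a stated time of 48 h, tested at 10 uM (a higher number here means more inhibition of growth at the concentration tested, a lower number less inhibition of growth), with 41% of growth inhibition. Compound 1 `Cc1oc2c([C@H]3CCN(C)C[C@H]3O)c(O)cc(O)c2c(=O)c1C(O)c1ccc(Cl)cc1` gives 6% in this assay and compound 2 `Cc1oc2c([C@H]3CCN(C)C[C@H]3O)c(O)cc(O)c2c(=O)c1C(O)c1ccc(F)c(Br)c1` gives 14% in the same test. Two measured steps lead up to the top value: a number 35 percentage points higher from compound 1 to compound 3 (beyond the scatter) with 3-bromo-4-methoxyphenyl in place of 4-chlorophenyl, and a number 27 percentage points higher from compound 2 to compound 3 (beyond the scatter) with methoxy in place of fluoro. The third step is small: a number 8 percentage points higher from compound 1 to compound 2 (within the scatter) between the two compounds without methoxy.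

Compound 4 `Cc1oc2c([C@H]3CCN(C)C[C@H]3O)c(O)cc(O)c2c(=O)c1C(O)c1cccc(Cl)c1Cl` has not been measured. Its change from compound 3 is 2,3-dichlorophenyl in place of 3-bromo-4-methoxyphenyl on a saturated chain carbon bound to an aromatic carbon and an oxygen on a saturated carbon so the methoxy is lost and 2,3-dichlorophenyl enters. Going by the values given here, no measured compound carries this exact group, which leaves the estimate uncertain. Compound 1 at 6% and compound 2 at 14% are the nearest guides, since neither has a methoxy. A drop of modest to large size is therefore expected, and the estimated step is a number 27 percentage points lower from compound 3 to compound 4 (beyond the scatter) in this assay as things stand. The estimate for compound 4 is 14% with 3% to 36% as the expected range.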

Compound 4, percent growth inhibition at one concentration: 7%
Beside the measured number, compound 4's estimate is 7 percentage points above it, within the range that was stated.
By their numbers in this assay, from the lowest: compounds 1, 4 and 2 (each within the scatter of the next); then compound 3.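

In this assay, putting 2,3-dichlorophenyl in place of 3-bromo-4-methoxyphenyl on this saturated chain carbon gives a number 34 percentage points lower from compound 3 to compound 4 (beyond the scatter) and extends the earlier picture to a third group without a methoxy. The other two steps, a number 7 percentage points lower from compound 2 to compound 4 (within the scatter) and a number 1 percentage points higher from compound 1 to compound 4 (within the scatter), leave 2,3-dichlorophenyl, 3-bromo-4-fluorophenyl and 4-chlorophenyl indistinguishable in this test, even though these groups differ in their halogens. Among these four compounds, only compound 3, the one with a methoxy, stands apart, and nothing measured here explains that gap.

From the compounds shown here alone, whether the methoxy achieves this alone or only together with the bromine remains open. Also open, going by these compounds, is how an amine such as dimethylamino, or a longer ether such as ethoxy, would read in this assay in place of the methoxy.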